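A few compounds are considered here, and "the series" means these few. Any claim that something is new, unique, unknown or untested is made for them only; others in the source may bear on it.

Of the compounds shown here, three have so far been measured in a functional assay on cells for agonist activity at Glucose-dependent insulinotropic receptor (Homo sapiens), read by a luciferase reporter, with a stated time of 4 h; a higher number here means a larger maximal response, a lower number a smaller maximal response. Compound 1 `CC(C)(C)OC(=O)N1CCC(c2coc3c(N4CCCc5cc(S(C)(=O)=O)ccc54)ncnc23)CC1` gives 1% there, a very small maximal response. Compound 3 `CC(C)(C)OC(=O)N1CCC(c2coc3c(Nc4ccc(S(C)(=O)=O)cc4F)ncnc23)CC1` gives 123%. Compound 2 `CCc1cnc(N2CCC(c3coc4c(N5CCc6cc(S(C)(=O)=O)ccc65)ncnc34)CC2)nc1` gives 154%, the highest of the three: its gap to compound 3 and its much larger gap to compound 1 both lie beyond the usual scatter of this kind of measurement, so compound 2 shows the largest maximal response among the measured compounds.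

Compound 4 `CC(O)c1cnc(N2CCC(c3coc4c(N5CCc6cc(S(C)(=O)=O)ccc65)ncnc34)CC2)nc1` has not yet been measured. It differs from compound 2 in one place: hydroxy in place of hydrogen on a saturated chain carbon bound to an aromatic carbon and a saturated chain carbon. Seen one bond further out, the ethyl of compound 2 becomes a 1-hydroxyethyl, so its 5-ethylpyrimidin-2-yl becomes 5-(1-hydroxyethyl)pyrimidin-2-yl. Going by the values given here, no measured pair in this set shows what such a change does, so no direction can be read from the data. A small step is expected, likely within the scatter or a little below compound 2, and the expected step from compound 2 to compound 4 is a number 14 percentage points lower from compound 2 to compound 4 (beyond the scatter). Compound 4 is therefore estimated to give 140% in this assay, with a likely range from 90% to 180%.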

Compound 4, largest response reached (Emax), in percent of the reference or control that the assay uses: 33%
Beside the measured number, compound 4's estimate is 107 percentage points above it, outside the stated range (below it).
By their numbers in this assay, from the lowest: compound 1; then compound 4; then compound 3; then compound 2.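

Going by these compounds alone, until now, no pair of compounds showed what a change at this saturated chain carbon does, and this pair shows that the position is highly sensitive. In this assay, within the data shown here, the only change is hydroxy in place of hydrogen, which turns ethyl into 1-hydroxyethyl, and the result is a number 121 percentage points lower from compound 2 to compound 4 (beyond the scatter) in a step that counts as large. The data on hand offer no explanation for how a single added oxygen can take away so much of the maximal response.

On these data alone, it remains open whether the loss belongs to hydroxy itself, or whether a methoxy or an amine at the same carbon would do the same. A longer chain such as propyl in place of ethyl is also untested here, so it is unclear how much room this position allows.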